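Pyrimidin-5-yl swap at the weak end of the series

The compounds below may be only part of what the source reports. "The series", "measured", "known", "first", "only" and "open" are said of these compounds alone.

In a functional assay on A549 cells (Homo sapiens) for inhibition, read by MTT assay, with a stated time of 48 h (on this read-out higher numbers stand for weaker inhibition and lower numbers for stronger inhibition), compound 1 `COc1ccc(-c2cc(NC(=O)Nc3ccccn3)cc(OC)c2OC)cn1` gives 24700 nM. Compound 3 `COc1ccc(-c2cc(NC(=O)Nc3ccncc3)cc(C(F)(F)F)c2)cn1` gives 276000 nM, the higher of these two numbers, and its gap to compound 1 lies beyond the scatter. Compound 2 `O=C(Nc1ccncc1)Nc1cc(-c2cccnc2)cc(C(F)(F)F)c1` reads > 300000 nM, which is a limit of the assay.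

Compound 4 `O=C(Nc1ccncc1)Nc1cc(-c2cncnc2)cc(C(F)(F)F)c1` differs from compound 3 by pyrimidin-5-yl in place of 6-methoxypyridin-3-yl on an aromatic carbon. Among the measured compounds shown here, the one measured step bearing on this change, methoxy in place of hydrogen on an aromatic carbon, is an at least 1.0-fold lower number from compound 2 to compound 3 (0.03 log units; that floor lies within the scatter). No change beyond the scatter is therefore expected in this assay. The estimated step is a 1.1-fold higher number from compound 3 to compound 4 (0.04 log units; within the scatter). Compound 4 is expected at 300000 nM, with an estimated range of 130000 nM to 700000 nM.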

Compound 4, half-maximal inhibitory concentration: 2420 nM
The estimate for compound 4 lay 120-fold (2.09 log units) above the measured number; the measured number lies below the stated range.
By their numbers in this assay, from the lowest: compound 4; then compound 1; then compound 3. At a limit, above all of these: compound 2.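

With the trifluoromethyl group kept, the read-out in this assay proves highly sensitive to the aromatic ring at this position: pyrimidin-5-yl gives a 110-fold lower number from compound 3 to compound 4 (2.06 log units; beyond the scatter) and, in place of pyridin-3-yl, an at least 120-fold lower number from compound 2 to compound 4 (2.09 log units; beyond the scatter). The earlier step, an at least 1.0-fold lower number from compound 2 to compound 3 (0.03 log units; that floor lies within the scatter), gave no sign of this sensitivity. The step from pyridin-3-yl is only a floor: the limit of > 300000 nM in this assay, at which 1 of the 4 values shown sits.

Still open, on these data alone, is whether an amine on the pyrimidin-5-yl ring would keep this gain. Also open, as far as these compounds go, is whether pyrimidin-5-yl would act likewise on the core of compound 1.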